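Changing the Ether Ring on a Shared Core

This account rests on a few compounds, and the source may have more. Where it says the series, first, only, none or still open, it means among the compounds named here.

Compound 1 `C[C@@H](Cn1c(=O)[nH]/c(=N\c2ccc(Oc3ccccn3)cc2)n(Cc2ccc(Cl)cc2)c1=O)C(=O)O`: in an assay on isolated protein for antagonist activity at P2X purinoceptor 4 (Homo sapiens) (on this read-out higher numbers stand for weaker inhibition and lower numbers for stronger inhibition), compound 1 gives > 30000 nM, which is a limit of the assay and not a number.
Compound 2 `C[C@@H](Cn1c(=O)[nH]/c(=N\c2ccc(Oc3ccnc(F)c3)cc2)n(Cc2ccc(Cl)cc2)c1=O)C(=O)O`: in this assay compound 2 gives > 30000 nM, again a limit of the assay rather than a number.

Compound 2 therefore stands at the limit of this assay, with no inhibition seen up to that concentration. For the measured compounds named here, the only measured step, a step that the two limits leave unreadable from compound 1 to compound 2, cannot be read, since both ends of it are limits; the shared point is the limit of > 30000 nM in this assay, at which 2 of the 2 values shown sit.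

Compound 3 `C[C@@H](Cn1c(=O)[nH]/c(=N\c2ccc(Oc3ccsn3)cc2)n(Cc2ccc(Cl)cc2)c1=O)C(=O)O` is not yet measured. It differs from compound 2 in one place: 1,2-thiazol-3-yl in place of 2-fluoropyridin-4-yl on an oxygen on an aromatic ring. Going by the values given here, the one measured step is the only comparison available, and it is unreadable, so it gives no direction for this change. Among the compounds with values here, with no measured compound giving a number at all, the step of a number no higher from compound 2 to compound 3 (the limit leaves the size open) is expected to show no inhibition beyond the scatter, and compound 3 is expected to remain at the limit. The estimate for compound 3 in this assay is 30000 nM, with a range from 8000 nM to 100000 nM.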

Compound 3, half-maximal inhibitory concentration: > 30000 nM
Compound 3: no number, only a limit; the forecaster's own chance of this, stated with the estimate: 80%; the middle value sits exactly at the limit.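

In this assay compound 3 gives > 30000 nM and this is a limit of the assay, not a number. The steps among compound 1, compound 2 and compound 3 therefore cannot be read, as all three share one point: the limit of > 30000 nM in this assay, at which 3 of the 3 values shown sit. Going by these compounds, whether any ring on that oxygen gives measurable inhibition on the shared core, and how such rings would rank, stays open.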